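Swapping a naphthalene for a trifluoromethoxyphenyl

The source may report more compounds than this note shows. Statements on the series, on what has been measured and on what is new or still open speak of the compounds shown alone.

Three compounds share a core built around a sulfonyl group and an amide, and all were tested in a functional assay on CHO cells for antagonist activity at 5-hydroxytryptamine receptor 6 (Homo sapiens), read by FLIPR; on this read-out higher numbers stand for weaker inhibition and lower numbers for stronger inhibition. Compound 1 `COc1cccc(N2CCN(C(=O)C3CN(S(=O)(=O)c4ccc(OC)c5ccccc45)c4ccccc43)CC2)c1` gives 63.1 nM, and compound 2 `CCN(CC)CCCNC(=O)C1CN(S(=O)(=O)c2ccc(OC)c3ccccc23)c2ccccc21` gives 79.4 nM. Compound 3 `CN1CCC(N(C)C(=O)C2CN(S(=O)(=O)c3cccc4c(Cl)cccc34)c3ccccc32)CC1` gives 5.01 nM, the lowest number of the three; its gaps to compound 1 and to compound 2 both lie beyond the usual scatter, so compound 3 is the strongest inhibitor among these.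

Compound 4 `CN1CCC(N(C)C(=O)C2CN(S(=O)(=O)c3ccc(OC(F)(F)F)cc3)c3ccccc32)CC1` has not yet been measured. It differs from compound 3 in one place: 4-(trifluoromethoxy)phenyl in place of 5-chloronaphthalen-1-yl on a sulfonyl sulfur. The two groups match in heavy-atom count, but a single aromatic ring replaces two, and one hydrogen-bond acceptor is added where none was before. Within the data shown here, no measured pair shows this kind of change, so the expectation rests on the structural change alone.

Such a change is expected to weaken inhibition modestly, with a step of a 4.0-fold higher number from compound 3 to compound 4 (0.60 log units; beyond the scatter) in this assay. Compound 4 is estimated to give 20 nM, within a range from 5 nM to 80 nM.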

Compound 4, inhibition constant: 20 nM
Beside the measured number, compound 4's estimate shows no gap at the digits printed; measured number inside the range.
By their numbers in this assay, from the lowest: compound 3; then compound 4; then compounds 1 and 2 (each within the scatter of the next).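

In this assay, placing 4-(trifluoromethoxy)phenyl in place of 5-chloronaphthalen-1-yl on the sulfonyl sulfur gives a 4.0-fold higher number from compound 3 to compound 4 (0.60 log units; beyond the scatter), the first change in a single place among these compounds. It shows that inhibition at this position is sensitive to the group on the sulfur, yet it weakens only modestly when one aromatic ring replaces two, the chlorine is lost and a hydrogen-bond acceptor enters. These differences arrive together, and no measurement shown here explains the change or separates their contributions.

An unsubstituted phenyl ring or an unsubstituted naphthalen-1-yl group on the same sulfur could help separate the effect of the ring count from that of the chlorine and the trifluoromethoxy group. As far as these compounds go, it also remains open whether this step would be similar with the amide portion of compound 1 or compound 2.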